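Swapping Chloro for Fluoro on a Triazole Hydrazone

A few compounds are considered here, and "the series" means these few. Any claim that something is new, unique, unknown or untested is made for them only; others in the source may bear on it.

Three compounds sharing a triazole core carrying a pyridyl group and a phenyl group have been tested in a functional assay on HepG2 cells (Homo sapiens) for inhibition, read by MTT assay, with a stated time of 48 h; a higher number here means a weaker inhibitor, a lower number a stronger inhibitor. Compound 1, `Fc1ccc(CSc2nnc(-c3ccncc3)n2-c2ccccc2)cc1`, gives 15600 nM. Compound 2, `Clc1ccc(CSc2nnc(-c3ccncc3)n2-c2ccccc2)cc1`, gives 16900 nM. The two differ only in one spot: fluoro in place of chloro on an aromatic carbon, and the result is a 1.1-fold lower number from compound 2 to compound 1 (0.03 log units; within the scatter). Compound 3, `O=C(CSc1nnc(-c2ccncc2)n1-c1ccccc1)N/N=C/c1ccc(Cl)cc1`, gives 11000 nM. Its number is the lowest of the three, yet it sits within the scatter of both compound 1 and compound 2, so no order among the three can be claimed. How the core of compound 3 differs from the core of compound 2 is not broken down here.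

Compound 4, `O=C(CSc1nnc(-c2ccncc2)n1-c1ccccc1)N/N=C/c1ccc(F)cc1`, has not yet been measured in this assay. It differs from compound 3 in exactly the way compound 1 differs from compound 2: fluoro in place of chloro on an aromatic carbon. The surroundings of the change are the same in both pairs, so this is the same change made on a different core. Among the measured compounds shown here, the only evidence for what it does is the step from compound 2 to compound 1, which stayed within the scatter. On that basis, the step from compound 3 to compound 4 is expected to be about a 1.0-fold lower number from compound 3 to compound 4 (0.02 log units; within the scatter), essentially flat. Compound 4 is therefore estimated to give about 10500 nM in this assay, most likely between 5000 nM and 22000 nM.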

Compound 4, half-maximal inhibitory concentration: 9330 nM
The estimate for compound 4 lay 1.1-fold (0.05 log units) above the measured number; measured number inside the range.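

Putting fluoro in place of chloro on the second core leaves the number in this assay essentially flat, with a 1.2-fold lower number from compound 3 to compound 4 (0.07 log units; within the scatter). The swap behaves alike on the two cores, as far as this assay can tell: the same change on two cores in this assay, a 1.1-fold lower number (0.03 log units; within the scatter) from compound 2 to compound 1 and a 1.2-fold lower number (0.07 log units; within the scatter) from compound 3 to compound 4, 1.1-fold (0.04 log units) apart, within the scatter of two such steps

This shows that, in these two pairs, the change from 4-chlorophenyl to 4-fluorophenyl stays too small to tell apart from ordinary repeat-to-repeat variation on either core, but it does not show that the two halogens are interchangeable in general, and neither step is large enough to reveal a small real effect shared by both cores or to test whether a larger effect would carry across in the same way.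

The compounds shown hold only chloro or fluoro at this place on the ring, so it remains open whether a methoxy, a nitro group, an amine or a carboxylic acid there would shift the number, and whether such a shift would be the same on both cores. The pyridyl and phenyl groups also stay the same throughout, leaving open what replacing either of them would do.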